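The compounds below may be only part of what the source reports. "The series", "measured", "known", "first", "only" and "open" are said of these compounds alone.

The measured compounds and their values:

Compound 1, `CCc1ccc(-c2nn3cc(-c4cccc(N)c4)nc3s2)cc1`, in a functional assay on L1210 cells (Mus musculus) for inhibition, read by cell counting, with a stated time of 2 days (a lower number here means a stronger inhibitor, a higher number a weaker inhibitor), compound 1 gives 6000 nM.
Compound 2, `C=C(Br)C(=O)Nc1cccc(-c2cn3nc(-c4ccc(CC)cc4)sc3n2)c1`, in this assay compound 2 gives 2200 nM.
Compound 3, `Nc1cccc(-c2cn3c(-c4ccccc4)csc3n2)c1`, in this assay compound 3 gives 85000 nM.

Compound 1 and compound 2 share a core and differ by (1-bromoethenyl)carbonyl in place of hydrogen on a nitrogen on an aromatic ring. That change made a 2.7-fold lower number from compound 1 to compound 2 (0.44 log units; beyond the scatter), a modest step but beyond the scatter. Compound 3 carries a different core; the difference between the two cores is not broken down here. Compound 3 gives the highest number of the three, and its gap to compound 1 lies beyond the scatter.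

Compound 4, `C=C(Br)C(=O)Nc1cccc(-c2cn3c(-c4ccccc4)csc3n2)c1`, is not yet measured. It differs from compound 3 by (1-bromoethenyl)carbonyl in place of hydrogen on a nitrogen on an aromatic ring, which is the same change that turns compound 1 into compound 2, made at a place whose surroundings are described in the same words. Within the data shown here, only one instance of the change is known. Resting on that single step, compound 4 is expected to show a 2.8-fold lower number from compound 3 to compound 4 (0.45 log units; beyond the scatter), a step of a size like the one from compound 1 to compound 2, because a 2.7-fold lower number from compound 1 to compound 2 (0.44 log units; beyond the scatter) was modest and beyond the scatter. Compound 4 is therefore estimated at 30000 nM, with a plausible range from 12000 nM to 80000 nM in this assay.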

Compound 4, half-maximal inhibitory concentration: 1300 nM
Estimate against measurement, compound 4: 23-fold (1.36 log units) above; measured number below the stated range.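

In this assay, putting (1-bromoethenyl)carbonyl in place of hydrogen on a nitrogen on an aromatic ring gave a 65-fold lower number from compound 3 to compound 4 (1.82 log units; beyond the scatter) and so a large step. Set beside the earlier step, the size of the change did not carry over from one core to the other: the same change on two cores in this assay, a 2.7-fold lower number (0.44 log units; beyond the scatter) from compound 1 to compound 2 and a 65-fold lower number (1.82 log units; beyond the scatter) from compound 3 to compound 4, 24-fold (1.38 log units) apart, beyond the scatter of two such steps.
The number fell on both cores, so the direction held in these two pairs, but two pairs give no rule for how large the step would be on a further core, and they do not show which feature of the cores goes with the difference in size.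

The compounds shown leave open whether a group without bromine, such as acetyl or propenoyl, on the same nitrogen would also give steps that differ so widely between the two cores. They also leave open whether replacing the ethyl group on the core of compound 2 with a longer chain or an amine would alter the size of the step.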